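A few compounds are considered here, and "the series" means these few. Any claim that something is new, unique, unknown or untested is made for them only; others in the source may bear on it.

Compound 1 `C=C(Br)C(=O)Nc1ccc(/C=C/C(=O)c2ccc(Cl)cc2)cc1`: 810 nM
Compound 2 `C=C(Br)C(=O)Nc1ccc(/C=C/C(=O)c2ccc(Br)cc2)cc1`: 680 nM
Compound 3 `C=C(Br)C(=O)Nc1ccc(/C=C/C(=O)c2ccc(I)cc2)cc1`: not yet measured

These numbers come from a functional assay on MOLT-4 cells (Homo sapiens) for antiproliferative activity, with a stated time of 48 h; on this read-out lower numbers stand for stronger inhibition and higher numbers for weaker inhibition. Compound 2 stands level with compound 1, since the two values lie within the usual scatter of repeated measurements. Compound 3 differs from compound 2 in a single place: iodo in place of bromo on an aromatic carbon. This is iodo in place of bromo on an aromatic carbon, para to a large group. Among the compounds with values here, one measured step bears on this change, the swap of chloro for bromo at the same place. That step is a 1.2-fold lower number from compound 1 to compound 2 (0.08 log units; within the scatter), so it is too small to separate the two compounds. One step cannot establish a trend, but it gives no reason to expect a real shift here, in either direction. The expected step is a 1.1-fold lower number from compound 2 to compound 3 (0.04 log units; within the scatter), which would stay within the scatter. For compound 3 the estimated value is 620 nM, with an expected range of 300 nM to 1300 nM.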

Compound 3, half-maximal inhibitory concentration: 2800 nM
Estimate against measurement, compound 3: 4.5-fold (0.65 log units) below; the measured number lies above the stated range.
By their numbers in this assay, from the lowest: compounds 2 and 1 (each within the scatter of the next); then compound 3.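

In this assay, iodo in place of bromo gives a 4.1-fold higher number from compound 2 to compound 3 (0.61 log units; beyond the scatter), and iodo in place of chloro gives a 3.5-fold higher number from compound 1 to compound 3 (0.54 log units; beyond the scatter). The halogen on this aromatic carbon therefore does matter, even though chloro and bromo could not be told apart, as their step of a 1.2-fold lower number from compound 1 to compound 2 (0.08 log units; within the scatter) stays within the scatter. Nothing measured here accounts for why iodo stands apart from the other two halogens.

The compounds shown leave open whether this weaker inhibition is particular to iodo or would also appear with quite different groups at this place, such as a methyl, an amine or a carboxylic acid. They also leave open whether the same swap from bromo to iodo would give a similar step on a different core.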